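A few compounds are considered here, and "the series" means these few. Any claim that something is new, unique, unknown or untested is made for them only; others in the source may bear on it.

Measured compounds in a functional assay on MCF7 cells (Homo sapiens) for cytotoxicity, read by sulforhodamine B assay; on this read-out lower numbers stand for an effect already at smaller amounts and higher numbers for an effect only at larger amounts of compound:

compound 1, `C=C1CC[C@@H]2[C@](C)(CO[Si](C)(C)C(C)(C)C)[C@H](O)CC[C@@]2(C)[C@@H]1C/C=C1/C(=O)OC[C@H]1OC(C)=O`, gives 10.4 uM
compound 2, `C=C1CC[C@@H]2[C@](C)(COC(C)=O)[C@H](O)CC[C@@]2(C)[C@@H]1C/C=C1/C(=O)OC[C@H]1O`, gives 18.3 uM

These two compounds share a core and differ in two places at once, so no single structural change can be read from their pair; all that can be said is that in this assay compound 2 gives 18.3 uM and compound 1 gives 10.4 uM, and these two values lie within the usual scatter of each other. Among the compounds with values here, compound 2 therefore stands close to the only other measured compound, with nothing to set the two apart.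

Compound 3, `C=C1CC[C@@H]2[C@](C)(COC(C)=O)[C@H](O)CC[C@@]2(C)[C@@H]1C/C=C1/C(=O)OC[C@H]1OC(C)=O`, has not yet been measured. It differs from compound 2 in one place: acetyl in place of hydrogen on an oxygen on a saturated carbon, so that a hydroxy group becomes an acetoxy group on the lactone ring while the acetate on the primary oxygen is kept. Within the data shown here, with no measured step of this kind available, the expectation rests on the closeness of compound 1 and compound 2 alone. The step from compound 2 to compound 3 in this assay is expected to be small, a 1.5-fold lower number from compound 2 to compound 3 (0.18 log units; within the scatter), and not clearly beyond the scatter. Compound 3 is therefore estimated at 12 uM, with a range from 5 uM to 30 uM.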

Compound 3, concentration for half-maximal effect: 18.5 uM
The estimate for compound 3 lay 1.5-fold (0.19 log units) below the measured number, and the stated range covers the measured number.
By their numbers in this assay, from the lowest: compounds 1, 2 and 3 (each within the scatter of the next).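

Within the data shown here, putting acetyl in place of hydrogen on an oxygen on a saturated carbon, which turns hydroxy into acetoxy, is the first change in one place that can be read in this assay: it gives a 1.0-fold higher number from compound 2 to compound 3 (0.00 log units; within the scatter) and so shows no effect that this read-out can separate from scatter. A second one-place comparison concerns the other oxygen, where a group of 3 heavy atoms (2 carbon, 1 oxygen) stands in place of a group of 7 heavy atoms (6 carbon, 1 silicon), and it gives a 1.8-fold higher number from compound 1 to compound 3 (0.25 log units; within the scatter) even though the two groups differ clearly in size and one contains silicon. Nothing further is available that bears on why these numbers stay so close.

Going by these compounds, what remains open is whether a different group on either oxygen, such as a longer chain like butanoyl or a group carrying an amine or a carboxylic acid, would move the number beyond the scatter. On these data alone, it is also open whether a free hydroxy on the oxygen that carries acetyl in both compound 2 and compound 3 would leave the number as close as these steps do.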